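A few compounds are considered here, and "the series" means these few. Any claim that something is new, unique, unknown or untested is made for them only; others in the source may bear on it.

In an in vitro ADME assay on microsomes from liver (Rattus norvegicus) for metabolic stability, read by LC-MS, tested at 1 uM (a higher number here means faster removal of the compound, a lower number slower removal), compound 1 (`CN(C)S(=O)(=O)c1ccc(F)c(C#Cc2cc(Cl)ccc2OCC(=O)O)c1`) gives < 10 mL.min-1.g-1, which is a limit of the assay and not a number. Compound 1 therefore stands at the limit of < 10 mL.min-1.g-1 in this assay, at which 1 of the 2 values shown sits. The other measured compound, compound 2 (`Cc1ccc(S(=O)(=O)N2CCCCC2C)cc1C#Cc1cc(Cl)ccc1OCC(=O)O`), gives a numerical value of 418 mL.min-1.g-1.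

Compound 3 (`Cc1ccc(S(=O)(=O)N(C)C)cc1C#Cc1cc(Cl)ccc1OCC(=O)O`) has methyl in place of fluoro on an aromatic carbon, ortho to a large group and para to a dimethylsulfamoyl group (methyl in place of fluoro on an aromatic carbon). Among the compounds with values here, no measured pair isolates this change, so any expectation remains tentative. Compound 2, which also carries methyl on this aromatic carbon, gives 418 mL.min-1.g-1, and this points to an upward move in this assay. The expected step is an at least 4.0-fold higher number from compound 1 to compound 3 (0.60 log units; beyond the scatter), a rise beyond the scatter. For compound 3 the estimated value is 40 mL.min-1.g-1, with an expected range of 12 mL.min-1.g-1 to 140 mL.min-1.g-1.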

Compound 3, intrinsic clearance in microsomes: 22 mL.min-1.g-1
For compound 3 the middle estimate is 1.8-fold (0.26 log units) above the measured one, and the stated range covers the measured number.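

In this assay, methyl in place of fluoro on an aromatic carbon, ortho to a large group and para to a dimethylsulfamoyl group, gives an at least 2.2-fold higher number from compound 1 to compound 3 (0.34 log units; beyond the scatter), so this position does respond to the change when the dimethylsulfamoyl group is held constant. With the methyl kept, dimethylamino in place of 2-methylpiperidin-1-yl on a sulfonyl sulfur gives a 19-fold lower number from compound 2 to compound 3 (1.28 log units; beyond the scatter), which shows that the group on the sulfonyl sulfur also matters, and by a large step. The value of compound 1 is a limit of the assay, so the first step has only a lower bound: the limit of < 10 mL.min-1.g-1 in this assay, at which 1 of the 3 values shown sits.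

On these data alone, how far that step reaches, and whether it would hold with 2-methylpiperidin-1-yl on the sulfonyl sulfur, stays open. The compounds shown also leave open how a methoxy group on this aromatic carbon or a morpholine on the sulfonyl sulfur would read in this assay.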